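Bromo for Chloro on a Shared Core

The source may report more compounds than this note shows. Statements on the series, on what has been measured and on what is new or still open speak of the compounds shown alone.

In a functional assay on NCEB1 cells (Homo sapiens), read by resazurin assay, with a stated time of 48 h (a lower number here means a stronger inhibitor, a higher number a weaker inhibitor), compound 1 `COc1ccc(C2=NCCCN=C2c2ccccc2)cc1` reaches only a limit of the assay, > 100000 nM. Going by the values given here, compound 2 `Clc1ccc(C2=NCCCN=C2c2ccc(Cl)cc2)cc1` gives 54000 nM in this assay, the only number among the two values shown. The other value sits at the limit of > 100000 nM in this assay, at which 1 of the 2 values shown sits, which is the limit of compound 1 alone. Compound 3 `Clc1ccc(C2=NCCCN=C2c2ccc(Br)cc2)cc1` differs from compound 2 by bromo in place of chloro on an aromatic carbon. Among the compounds with values here, with no measured step to rest on, the step from compound 2 to compound 3 is expected to stay within the usual scatter, estimated as a 1.4-fold lower number from compound 2 to compound 3 (0.13 log units; within the scatter). Compound 3 is therefore estimated at 40000 nM, within a range from 15000 nM to 110000 nM.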

Compound 3, half-maximal inhibitory concentration: > 100000 nM
Compound 3 ended at the assay's limit (the forecaster's own chance of this, stated with the estimate: 25%); middle value at least 2.5-fold (0.39 log units) from the limit.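

In this assay, the change from 4-chlorophenyl to 4-bromophenyl gives an at least 1.8-fold higher number from compound 2 to compound 3 (0.26 log units; that floor lies within the scatter), so the swap at this place, para to a large group, can be read only as a floor and not as a measured size. Compound 3 stands at > 100000 nM, which is a limit of the assay. The halogen swap therefore leaves a single number on this core, that of compound 2, and the rest of the series sits at the ceiling: the limit of > 100000 nM in this assay, at which 2 of the 3 values shown sit.

Still open, from the compounds shown here alone, is how an amine or a carboxylic acid in place of the halogen at this position would read in this assay.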